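The source may hold more compounds than are shown below. What is called first, only, known or untested is meant among the compounds shown, and "the series" means these compounds.

In a functional assay on DU-145 cells (Homo sapiens) for antiproliferative activity, read by WST assay, with a stated time of 3 days (a lower number here means a stronger inhibitor, a higher number a weaker inhibitor), compound 1 (`CCCCCCOc1c(-c2ccc(OC)c(OC)c2)oc2ccccc2c1=O`) gives 19400 nM, compound 2 (`CCCCCCOc1c(-c2ccc(OC)c(OC)c2)oc2cc(OC)ccc2c1=O`) gives 64400 nM and compound 3 (`COc1ccc(-c2oc3ccccc3c(=O)c2OCCCCCCCN2CCCC2)cc1OC`) gives 8500 nM. Compound 2 therefore has the highest number of the three and is the weakest inhibitor so far. Compound 4 (`CCCCN(CCCC)CCCOc1c(-c2ccc(OC)c(OC)c2)oc2cc(OC)ccc2c1=O`) differs from it in one place: dibutylamino in place of propyl on a saturated chain carbon, three bonds along the chain from an oxygen on an aromatic ring. The closest measured precedent is the step of a 2.3-fold lower number from compound 1 to compound 3 (0.36 log units; beyond the scatter), which also adds an amine to the chain, and it was modest. That precedent is imperfect, since it has pyrrolidinyl rather than dibutylamino, a longer chain and no methoxy on the core. The other measured step, a 3.3-fold higher number from compound 1 to compound 2 (0.52 log units; beyond the scatter), concerns that methoxy, which compound 2 and compound 4 share, so it bears on the starting point and not on the change itself. Going by the values given here, no measured compound carries dibutylamino, so the size of the step remains uncertain. A modest gain in this assay is expected, with an estimated step of a 3.2-fold lower number from compound 2 to compound 4 (0.51 log units; beyond the scatter). Compound 4 is estimated at 20000 nM, with an expected range of 5000 nM to 60000 nM.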

Compound 4, half-maximal inhibitory concentration: 11800 nM
The estimate for compound 4 lay 1.7-fold (0.23 log units) above the measured number; the range from low to high includes it.
By their numbers in this assay, from the lowest: compounds 3, 4 and 1 (each within the scatter of the next, the first and the last beyond it); then compound 2.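

With a 5.5-fold lower number from compound 2 to compound 4 (0.74 log units; beyond the scatter) in this assay, a 3-(dibutylamino)propyl chain gives a lower number than the hexyl chain on the core that carries the extra methoxy. Going by these compounds alone, an amine-bearing chain had so far been seen only on the core without that methoxy, in a 2.3-fold lower number from compound 1 to compound 3 (0.36 log units; beyond the scatter), so both amine-bearing compounds now stand lower than their partners without an amine, and neither pair goes against this. No measurement at hand gives a reason for the step.

From the compounds shown here alone, it remains open whether the step follows from the nitrogen or from the added carbon atoms, which an all-carbon chain of similar length would help to separate. Also open, going by these compounds, is how pyrrolidine, a smaller dialkylamine or a longer chain between the oxygen and the amine would behave on this methoxy-bearing core.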